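This account rests on a few compounds, and the source may have more. Where it says the series, first, only, none or still open, it means among the compounds named here.

Compound 1 `Cc1cc2nc(C)c(CN)c(-c3ccc(Cl)cc3Cl)n2n1` gives > 30000 nM in an assay on isolated protein for inhibition of Dipeptidyl peptidase 9 (Homo sapiens) (a lower number here means a stronger inhibitor, a higher number a weaker inhibitor), which is a limit of the assay and not a number.
Compound 2 `CCN(CC)c1nc2nc(C)c(CN)c(-c3ccc(Cl)cc3Cl)n2n1` gives > 30000 nM in this assay, again a limit.
Compound 3 `Cc1nc2nc(N3CCN(C(=O)OC(C)(C)C)CC3)nn2c(-c2ccc(Cl)cc2Cl)c1CN` gives > 30000 nM in this assay, also a limit.

Compound 1 therefore stands nowhere on a scale of numbers: its value is a limit, and the same is true of compound 2 and compound 3, as the limit of > 30000 nM in this assay, at which 3 of the 3 values shown sit, records. Among the compounds with values here, no step between measured compounds exists in this set. Compound 4 `Cc1ccc(-c2cc3nc(C)c(CN)c(-c4ccc(Cl)cc4Cl)n3n2)cc1` differs from compound 1 by 4-methylphenyl in place of methyl on an aromatic carbon. Within the data shown here, with no measured step to lean on, and compound 1 itself at the limit, no direction beyond the scatter can be claimed for the change in this assay. Compound 4 is expected near 30000 nM, between 5000 nM and 100000 nM. The expected step from compound 1 to compound 4 is a number no higher from compound 1 to compound 4 (the limit leaves the size open).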

Compound 4, inhibition constant: > 10000 nM
Compound 4: no number, only a limit; the forecaster's own chance of this, stated with the estimate: 75%; the middle value lies beyond the limit too.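

Compound 1 and compound 4 both stand at limits, so the step between them cannot be read. The compounds shown leave open which structural change, if any, would give a measurable value in this assay.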